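A few compounds are considered here, and "the series" means these few. Any claim that something is new, unique, unknown or untested is made for them only; others in the source may bear on it.

Compound 1 `CC#CCCOc1cccc2ccc(N)nc12` and compound 2 `CNc1ccc2cccc(OC(C)CC(C)(C)C)c2n1` share the core. In an assay on cells with melanin-concentrating hormone receptor 1 (Homo sapiens) as the target, read by radioligand binding (a higher number here means a weaker inhibitor, a lower number a stronger inhibitor), compound 1 gives only the assay limit of > 2000 nM, so no number is known for it. On the values shown compound 1 stands at the limit of > 2000 nM in this assay, at which 1 of the 2 values shown sits. Compound 2 gives 310 nM in this assay. Compound 3 `CC(C)(C)CCOc1cccc2ccc(N)nc12` carries tert-butyl in place of prop-1-yn-1-yl on a saturated chain carbon, two bonds along the chain from an oxygen on an aromatic ring. Among the measured compounds shown here, no measured pair isolates this change, so its size is uncertain; a moderate gain is expected, since compound 1 sits at the limit of > 2000 nM in this assay, at which 1 of the 2 values shown sits, and any improvement can only bring a number. The expected step is an at least 2.5-fold lower number from compound 1 to compound 3 (0.39 log units; beyond the scatter), toward stronger inhibition. For compound 3 the estimate in this assay is 800 nM, with a range from 200 nM to 3000 nM.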

Compound 3, half-maximal inhibitory concentration: 201 nM
Compound 3: middle estimate off by 4.0-fold (0.60 log units), on the high side, and the stated range covers the measured number.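

In this assay, tert-butyl in place of prop-1-yn-1-yl on a saturated chain carbon, two bonds along the chain from an oxygen on an aromatic ring, gives an at least 9.9-fold lower number from compound 1 to compound 3 (0.99 log units; beyond the scatter). This single change, with the rest of compound 1 kept, is enough to bring a measurable number at this position. The step remains a lower bound because compound 1 gives a limit and not a number: the limit of > 2000 nM in this assay, at which 1 of the 3 values shown sits.

Still open, on these data alone, is whether the gain follows from the tert-butyl itself or from the loss of the triple bond. A plain propyl or a cyclohexyl at the same place would separate the two.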